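The source may hold more compounds than are shown below. What is called first, only, known or untested is meant among the compounds shown, and "the series" means these compounds.

Compounds measured in a functional assay on SK-MEL-28 cells (Homo sapiens) for inhibition, read by sulforhodamine B assay, with a stated time of 48 h; a lower number here means a stronger inhibitor of growth, a higher number a weaker inhibitor of growth: compound 1 `COc1cc(C)cc(-c2nn(CC#N)cc2-c2ccc(-c3cccc(C(C)=O)c3)nc2)c1` gives 93600 nM. Compound 2 `Cc1cc(O)cc(-c2nn(CC#N)cc2-c2ccnc(-c3ccc(Oc4ccccc4)cc3)c2)c1` gives 17000 nM. For compound 3 `COc1cc(C)cc(-c2nn(CC#N)cc2-c2ccnc(-c3ccc(N(C)C)cc3)c2)c1` only a limit is recorded, > 100000 nM.

Compound 3 therefore stands at the edge of what this assay reports: its entry is a limit, not a number, and it is the one entry that sits there (the limit of > 100000 nM in this assay, at which 1 of the 3 values shown sits). Compound 4 `Cc1cc(O)cc(-c2nn(CC#N)cc2-c2ccnc(-c3ccc(N(C)C)cc3)c2)c1` differs from compound 3 by hydrogen in place of methyl on an oxygen on an aromatic ring. Among the compounds with values here, no pair of measured compounds differs in exactly this one place, so the size of the step is not known from a measured pair. Compound 2, which carries the hydroxy group, gives a lower number than compound 1, which carries the methoxy group, but those two also differ elsewhere. Compound 4 is expected to move toward stronger inhibition by an at least 2.0-fold lower number from compound 3 to compound 4 (0.30 log units; that floor lies within the scatter), to an estimated 50000 nM, ranging from 15000 nM to 150000 nM.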

Compound 4, concentration for total growth inhibition: 32400 nM
Compound 4: the middle estimate sits 1.5-fold (0.19 log units) above what was measured, within the range that was stated.
By their numbers in this assay, from the lowest: compounds 2 and 4 (each within the scatter of the next); then compound 1. At a limit, above all of these: compound 3.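

In this assay, within the data shown here, the pair gives the first direct reading of methoxy to hydroxy on the aromatic ring, as an at least 3.0-fold lower number from compound 3 to compound 4 (0.48 log units; beyond the scatter). That size is only a floor, as the entry for compound 3 is a limit: the limit of > 100000 nM in this assay, at which 1 of the 4 values shown sits. With the hydroxy group kept, the other end of the molecule tolerates dimethylamino in place of phenoxy, as a 1.9-fold higher number from compound 2 to compound 4 (0.28 log units; within the scatter).

As far as these compounds go, it remains open whether the hydroxy group's hydrogen matters or only the loss of the methyl. An amine or an ethoxy group on that aromatic carbon would bear on this.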